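This account rests on a few compounds, and the source may have more. Where it says the series, first, only, none or still open, it means among the compounds named here.

In a functional assay on A549 cells (Homo sapiens) for inhibition, read by MTT assay, with a stated time of 72 h (a lower number here means a stronger inhibitor, a higher number a weaker inhibitor), compound 1 `COc1ccc(NC(=O)C2CCN(C/C=C/c3ccccc3)CC2)cc1` reads 83800 nM while compound 2 `O=C(Nc1cccc(Cl)c1)C1CCN(C/C=C/c2ccccc2)CC1` reads 19100 nM and compound 3 `O=C(Nc1cccc(Br)c1)C1CCN(C/C=C/c2ccccc2)CC1` reads 16500 nM on the same scale. The exchange of chloro for bromo (a 1.2-fold lower number from compound 2 to compound 3 (0.06 log units; within the scatter)) lies within the scatter, so compound 3 stands level with compound 2 at the low end of the three numbers. Compound 4 `O=C(NCc1ccccc1)C1CCN(C/C=C/c2ccccc2)CC1` carries benzyl in place of 3-bromophenyl on an amide-type nitrogen. For the measured compounds named here, no measured step reaches benzyl. The nearest guides are the modest changes on that same nitrogen (a 4.4-fold lower number from compound 1 to compound 2 (0.64 log units; beyond the scatter) and a 5.1-fold lower number from compound 1 to compound 3 (0.71 log units; beyond the scatter)), so a modest rise in the number is expected (a 2.1-fold higher number from compound 3 to compound 4 (0.33 log units; beyond the scatter)). Compound 4 is estimated at 35000 nM in this assay (from 14000 nM to 90000 nM).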

Compound 4, half-maximal inhibitory concentration: > 100000 nM
Compound 4 ended at the assay's limit (the forecaster's own chance of this, stated with the estimate: 15%); at least 2.8-fold (0.45 log units) between middle value and limit.
By their numbers in this assay, from the lowest: compounds 3 and 2 (each within the scatter of the next); then compound 1. At a limit, above all of these: compound 4.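

In this assay, benzyl in place of 3-bromophenyl on the amide-type nitrogen gives an at least 6.0-fold higher number from compound 3 to compound 4 (0.78 log units; beyond the scatter), although the two groups have the same count of heavy atoms and one aromatic ring each, and benzyl in place of 3-chlorophenyl gives an at least 5.2-fold higher number from compound 2 to compound 4 (0.71 log units; beyond the scatter). Compound 4 stands at a limit of the assay, not at a number: the limit of > 100000 nM in this assay, at which 1 of the 4 values shown sits. With an at least 1.1-fold higher number from compound 1 to compound 4 (0.07 log units; that floor lies within the scatter), benzyl cannot be ordered against 4-methoxyphenyl.

The compounds shown leave open whether a bromo or chloro on the benzyl ring, or a longer phenethyl chain on that nitrogen, would bring the number back down.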